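A few compounds are considered here, and "the series" means these few. Any claim that something is new, unique, unknown or untested is made for them only; others in the source may bear on it.

Measured so far:
compound 1 `NC(=O)c1nc(N2CCN(C(=O)COc3ccc(Cl)cc3)CC2)c2cc(F)sc2n1`: > 10000 nM
compound 2 `Nc1nc(N2CCN(C(=O)COc3ccccc3)CC2)c2ccsc2n1`: 780 nM

In a functional assay on cells (Lymphocyte) (on this read-out higher numbers stand for weaker inhibition and lower numbers for stronger inhibition), compound 1 gives only a limit, > 10000 nM, and no number; this is the limit of > 10000 nM in this assay, at which 1 of the 2 values shown sits. For the measured compounds named here, compound 2 gives 780 nM in this assay and so stands as the only number in the set. Compound 3 `Nc1nc(N2CCN(C(=O)COc3ccc(F)cc3)CC2)c2ccsc2n1` has not yet been measured. It differs from compound 2 by fluoro in place of hydrogen on an aromatic carbon, the phenoxy becoming a 4-fluorophenoxy with nothing else altered. Going by the values given here, no step between two measured compounds is available to calibrate this change, and compound 1 differs from compound 2 in several places at once, so its limit says nothing about the fluoro on its own. A change of this kind is expected to leave the reading close to that of compound 2, with a step of a 1.1-fold lower number from compound 2 to compound 3 (0.05 log units; within the scatter) that stays within the scatter in either direction. Compound 3 is therefore estimated at 700 nM in this assay, between 300 nM and 1600 nM.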

Compound 3, half-maximal inhibitory concentration: 66 nM
Estimate against measurement, compound 3: 11-fold (1.03 log units) above; measured number below the stated range.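

Fluoro in place of hydrogen on an aromatic carbon, para to a large group, gives a 12-fold lower number from compound 2 to compound 3 (1.07 log units; beyond the scatter) in this assay. For the compounds shown here, this is the first calibrated step, and it shows that the phenoxy ring is a place where one added atom can move the read-out well beyond the scatter, although it rests on this single pair. Nothing measured here accounts for the size of this step.

As far as these compounds go, it remains open whether the step belongs to fluoro in particular or to any substituent on this carbon, which a methyl, a methoxy or a nitrile at the same place would help to separate. From the compounds shown here alone, it also remains open whether a fluoro on another carbon of the phenoxy ring would give a comparable step.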